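The source may report more compounds than this note shows. Statements on the series, on what has been measured and on what is new or still open speak of the compounds shown alone.

Compound 1 `CC(C)(C)OC(=O)N1CCC[C@H]1COCCCCCCCC/C=C/c1ccc(-c2ccccc2)cc1` and compound 2 `CC(C)(C)OC(=O)N1CCC[C@H]1COCCCCCCCCC/C=C/c1ccc(-c2ccccc2)cc1` share a core; the difference between the two cores is not broken down here. In a functional assay on MIA PaCa-2 cells (Homo sapiens) for inhibition, read by MTT assay, with a stated time of 72 h (on this read-out lower numbers stand for stronger inhibition and higher numbers for weaker inhibition), compound 1 gives 69200 nM. In this assay compound 2 gives 57400 nM. Compound 3 `CC(C)(C)OC(=O)N1CCC[C@H]1COCCCCCCCC/C=C/c1ccc(Oc2ccccc2)cc1` carries the change (phenoxy in place of phenyl on an aromatic carbon). In this assay compound 3 reaches only a limit, > 100000 nM, which is the limit of > 100000 nM in this assay, at which 1 of the 3 values shown sits. That change gave a step of an at least 1.4-fold higher number from compound 1 to compound 3 (0.15 log units; that floor lies within the scatter). Compound 4 `CC(C)(C)OC(=O)N1CCC[C@H]1COCCCCCCCCC/C=C/c1ccc(Oc2ccccc2)cc1` carries the same change, (phenoxy in place of phenyl on an aromatic carbon). Among the compounds with values here, compound 4 is expected to show a step of a 1.9-fold higher number from compound 2 to compound 4 (0.28 log units; within the scatter) from compound 2, resting on the one earlier step of an at least 1.4-fold higher number from compound 1 to compound 3 (0.15 log units; that floor lies within the scatter) and on compound 3 sitting at the limit of > 100000 nM in this assay, at which 1 of the 3 values shown sits. Compound 4 is therefore estimated at 110000 nM, between 55000 nM and 300000 nM, and may well return only a limit.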

Compound 4, half-maximal inhibitory concentration: 59600 nM
Compound 4: middle estimate off by 1.8-fold (0.27 log units), on the high side, and the stated range covers the measured number.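

In this assay, putting phenoxy in place of phenyl on the core of compound 2 gives a 1.0-fold higher number from compound 2 to compound 4 (0.02 log units; within the scatter), so on this core the change produces no shift beyond the usual scatter. Compound 3 gives > 100000 nM, which is a limit and not a number. Whether the change behaves the same way on both cores cannot be settled, because one of the two steps rests on that limit: the same change on two cores in this assay, an at least 1.4-fold higher number (0.15 log units; that floor lies within the scatter) from compound 1 to compound 3 and a 1.0-fold higher number (0.02 log units; within the scatter) from compound 2 to compound 4; the limit leaves it open whether they differ

The compounds shown leave open how an amine or a carboxylic acid would compare with phenyl and phenoxy on the same aromatic carbon. They also leave open whether the result would hold with a longer chain.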